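Methylating the Hydroxy Group of Compound 1

The compounds below may be only part of what the source reports. "The series", "measured", "known", "first", "only" and "open" are said of these compounds alone.

Measured compounds:
compound 1 `O=C(Nc1cccc(-n2cc(-c3ccncc3)c(-c3cc(O)cc(Cl)c3)n2)c1)Nc1ccc(Cl)c(C(F)(F)F)c1` — 99%
compound 2 `O=C(Nc1cccc(-n2cc(-c3ccncc3)c(-c3cc(O)cc(Cl)c3)n2)c1)Nc1ccc(Cl)c(Cl)c1` — 56%

In a functional assay on OVCAR-8 cells (Homo sapiens) for inhibition, read by sulforhodamine B assay, with a stated time of 48 h, tested at 1 uM (on this read-out higher numbers stand for a weaker effect at the one concentration tested and lower numbers for a stronger effect), compound 1 gives 99%, the highest of the two numbers recorded and therefore the weaker effect at the single concentration tested. For the measured compounds named here, its only neighbour is compound 2, and the step of a number 43 percentage points lower from compound 1 to compound 2 (beyond the scatter) arises from chloro in place of trifluoromethyl on an aromatic carbon.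

Compound 3 `COc1cc(Cl)cc(-c2nn(-c3cccc(NC(=O)Nc4ccc(Cl)c(C(F)(F)F)c4)c3)cc2-c2ccncc2)c1` has not yet been measured. It differs from compound 1 in one place: methyl in place of hydrogen on an oxygen on an aromatic ring. Going by the values given here, no measured pair shares this change; the one step known, a number 43 percentage points lower from compound 1 to compound 2 (beyond the scatter), alters a different part of the molecule and says nothing about the hydroxy group. With compound 1 already close to the top of the scale in this assay, there is little room for the number to rise, and no evidence that a methyl on the oxygen would pull it down.

For compound 3 the expected step of a number 7 percentage points lower from compound 1 to compound 3 (within the scatter) is small and within the scatter. Compound 3 is thus estimated to give 92%, within a range from 68% to 105%.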

Compound 3, a percentage reported as activity, at one concentration (the size of the read-out at that concentration, not a potency): 43%
Estimate against measurement, compound 3: 49 percentage points above, and the stated range ends above it.
By their numbers in this assay, from the lowest: compound 3; then compound 2; then compound 1.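

In this assay, the change from hydroxy to methoxy gives a number 56 percentage points lower from compound 1 to compound 3 (beyond the scatter), so this oxygen on the aromatic ring is a position where a single added methyl moves the read-out towards a stronger effect at the one concentration tested. Compound 1 and compound 2 both carry the hydroxy group and differ only at the other end of the molecule, so they could say nothing about this position, whereas compound 3 shows that the hydrogen on this oxygen is not required for an effect in this read-out and that replacing it with methyl gives a clear gain. Nothing in the available data explains why this change has such a large effect.

The compounds shown leave open whether the gain is specific to methyl or would extend to a longer chain on the same oxygen, such as ethoxy, or to an amine in place of the hydroxy group. They also leave open whether methoxy and the chloro in place of trifluoromethyl would add up when combined in one molecule, since no compound shown carries both changes.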